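Iodo to phenyl at the limit of a toxicity test

The source may hold more compounds than are shown below. What is called first, only, known or untested is meant among the compounds shown, and "the series" means these compounds.

Compound 1 `O=C(/C=C/c1ccc([N+](=O)[O-])o1)c1ccc(I)cc1` sits at the edge of what an ADME assay on Vero cells (Chlorocebus sabaeus) for cytotoxicity, read by resazurin assay, with a stated time of 72 h (on this read-out lower numbers stand for higher toxicity in this test and higher numbers for lower toxicity in this test), can report. In this assay compound 1 gives > 100000 nM, which is a limit and not a number. Compound 2 `CC(C)(C)c1ccc(C(=O)/C=C/c2ccc([N+](=O)[O-])o2)cc1` gives > 100000 nM, which is also a limit. Compound 3 `O=C(/C=C/c1ccc([N+](=O)[O-])s1)c1ccc(-n2ccnc2)cc1` gives a true number, 42700 nM, so this test can return a reading for a compound of this kind. On these data alone, the overall picture is the limit of > 100000 nM in this assay, at which 2 of the 3 values shown sit, and the exact standing of compound 1 stays unknown.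

Compound 4 `O=C(/C=C/c1ccc([N+](=O)[O-])o1)c1ccc(-c2ccccc2)cc1` changes one place in compound 1: phenyl in place of iodo on an aromatic carbon. In words, phenyl takes the place of iodo on an aromatic carbon, para to a large group. Among the measured compounds shown here, the only measured step at this place is a step that the two limits leave unreadable from compound 1 to compound 2, where tert-butyl replaces iodo, so it gives no size to carry over. On the strength of that step, no clear change is expected in this assay. If a number does appear, it should lie toward the lower, more toxic side, since the test cannot report beyond its limit. The expected step is an at least 1.2-fold lower number from compound 1 to compound 4 (0.09 log units; that floor lies within the scatter). For compound 4 the estimated value is 80000 nM, with an expected range from 35000 nM to 100000 nM.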

Compound 4, half-maximal cytotoxic concentration: > 100000 nM
Compound 4: a limit, no number (the forecaster's own chance of this, stated with the estimate: 65%); middle value at least 1.2-fold (0.09 log units) from the limit.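

Among the compounds shown here, compound 1, compound 2 and compound 4 all give limits and not numbers, and no step from compound 1 to compound 4 or from compound 2 to compound 4 can be read. What stays open is how far each of these three compounds lies from that limit, and whether iodo, tert-butyl and phenyl differ at all in this assay, for all three stand at the same edge: the limit of > 100000 nM in this assay, at which 3 of the 4 values shown sit.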